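The source may report more compounds than this note shows. Statements on the series, on what has been measured and on what is new or still open speak of the compounds shown alone.

Working notes on the series. Two compounds have numbers in a functional assay on MV4-11 cells (Homo sapiens) for antiproliferative activity, with a stated time of 6 days, tested at 1.56 uM (on this read-out lower numbers stand for a weaker effect and higher numbers for a stronger effect at the one concentration tested), so far. Compound 1 `CNC(=O)N1CCCc2ccc(NC(=O)c3ccc(-c4ccn(C(C)=O)n4)cc3)cc21` gives 35.8% in this assay and stands highest of the two; compound 2 `CNC(=O)N1CCCc2ccc(NC(=O)c3ccccc3-c3ccccc3)cc21`, a different amide partner on the shared core, gives 10.7% in this assay, a gap beyond the usual scatter. For the measured compounds named here, no two measured compounds differ in a single place, so no step between measured compounds can be read.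

Compound 3 `CNC(=O)N1CCCc2ccc(NC(=O)c3ccc(-c4cnn(C(C)=O)c4)cc3)cc21` is not yet measured. It keeps every atom of compound 1 but joins the five-membered ring through a different carbon: 1-acetyl-1H-pyrazol-4-yl in place of 1-acetyl-1H-pyrazol-3-yl on an aromatic carbon. Going by the values given here, with no measured pair to calibrate a change of this kind, the expected step from compound 1 to compound 3 in this assay is a number 4.8 percentage points lower from compound 1 to compound 3 (within the scatter), with no clear direction and not beyond the scatter. Compound 3 is therefore estimated at 31% in this assay, with a range from 12% to 52%.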

Compound 3, a percentage reported as inhibition, at one concentration (the size of the read-out at that concentration, not a potency): 23.9%
Estimate against measurement, compound 3: 7.1 percentage points above; low and high end bracket the measured number.
By their numbers in this assay, from the lowest: compound 2; then compound 3; then compound 1.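

In this assay, 1-acetyl-1H-pyrazol-4-yl in place of 1-acetyl-1H-pyrazol-3-yl gives a number 11.9 percentage points lower from compound 1 to compound 3 (beyond the scatter) with no atom gained or lost, so the way the five-membered ring is joined matters on its own. This position, on an aromatic carbon para to a large group, therefore responds to a change of attachment alone, although the step is modest and the effect of both compounds at the one concentration tested remains partial. Nothing available here accounts for the step.

Open is whether the acetyl group is needed at either attachment: the compounds shown include no pyrazole bearing a methyl group or a carboxylic acid in its place. Steps to compound 2 cannot be read, and the effect of a simple amine on the same ring remains unknown.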